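This account rests on a few compounds, and the source may have more. Where it says the series, first, only, none or still open, it means among the compounds named here.

In a functional assay on HeLa cells (Homo sapiens) for inhibition, read by sulforhodamine B assay, with a stated time of 48 h (on this read-out higher numbers stand for weaker inhibition of growth and lower numbers for stronger inhibition of growth), three compounds have been measured:
compound 1, `COC(=O)[C@@]1(C)CCC=C2[C@@H]1CC[C@@H](C)[C@]2(C)Cc1c[nH]c2ccc(Br)cc12`: 10000 nM
compound 2, `COC(=O)[C@@]1(C)CCC=C2[C@@H]1CC[C@@H](C)[C@]2(C)Cc1c[nH]c2ccc(Cl)cc12`: 11000 nM
compound 3, `COC(=O)[C@@]1(C)CC[C@@H]2C3=C1CC[C@@H](C)[C@]3(C)C[C@@H]1c3cccc(Br)c3N[C@H]21`: 22000 nM

Compound 1 and compound 2 share one core and differ at a single halogen: chloro in place of bromo on an aromatic carbon. This swap gave a 1.1-fold higher number from compound 1 to compound 2 (0.04 log units; within the scatter). Compound 3 is built from the same atoms as compound 1, joined differently; the difference between the two cores is not broken down here. Compound 3 sits within the scatter of compound 2 but beyond it relative to compound 1.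

Compound 4, `COC(=O)[C@@]1(C)CC[C@@H]2C3=C1CC[C@@H](C)[C@]3(C)C[C@@H]1c3cccc(Cl)c3N[C@H]21`, has not yet been measured. It stands to compound 3 as compound 2 stands to compound 1: chloro in place of bromo on an aromatic carbon. The surroundings differ, though: in compound 1 the halogen sits on a ring in a fused system of two rings, meta and para to a fused ring, whereas in compound 3 it sits on a ring in a fused system of five rings, ortho and meta to a fused ring. It is thus the same kind of change, not the same one.

The step from compound 3 to compound 4 is expected to be a 1.1-fold higher number from compound 3 to compound 4 (0.04 log units; within the scatter), because the earlier swap gave a 1.1-fold higher number from compound 1 to compound 2 (0.04 log units; within the scatter). Compound 4 is therefore estimated at 24000 nM, most likely between 9000 nM and 60000 nM.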

Compound 4, concentration for 50% growth inhibition: 31000 nM
The estimate for compound 4 lay 1.3-fold (0.11 log units) below the measured number; measured number inside the range.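

In this assay, for the compounds shown here, chloro in place of bromo on an aromatic carbon gave a 1.4-fold higher number from compound 3 to compound 4 (0.15 log units; within the scatter), so on this second core, as on the first, the swap produced no step that can be told apart from ordinary repeat variation. Set side by side, the two cores agree on this change: the same change on two cores in this assay, a 1.1-fold higher number (0.04 log units; within the scatter) from compound 1 to compound 2 and a 1.4-fold higher number (0.15 log units; within the scatter) from compound 3 to compound 4, 1.3-fold (0.11 log units) apart, within the scatter of two such steps. This shows that, for these two pairs, the swap between these two halogens carried from one core to the other without a detectable difference, but it does not show that a change with a larger effect would carry over in the same way, since two small steps are a weak test of transfer.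

The compounds shown hold only bromo or chloro on the aromatic ring, so it remains open how fluoro, a methoxy group or an amine would behave there. As far as these compounds go, it also remains open whether such a group would give matching steps on both cores.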